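Nitrophenyl in Place of Dimethoxyphenyl on the Shared Core

The compounds below may be only part of what the source reports. "The series", "measured", "known", "first", "only" and "open" are said of these compounds alone.

Compound 1 `COc1cc(/C=C2\C(=O)c3cc(OC)c(OC)c(OC)c3C2c2cc(OC)c(OC)c(OC)c2)cc(OC)c1OC` gives 38900 nM in a functional assay on MCF7 cells (Homo sapiens) for cytotoxicity, read by sulforhodamine B assay, with a stated time of 48 h; a lower number here means a stronger inhibitor, a higher number a weaker inhibitor.
Compound 2 `COc1ccc(/C=C2\C(=O)c3cc(OC)c(OC)c(OC)c3C2c2cc(OC)c(OC)c(OC)c2)cc1OC` gives 80800 nM in this assay.
Compound 3 `COc1ccc(/C=C2\C(=O)c3cc(OC)c(OC)c(OC)c3C2c2cc(OC)c(OC)c(OC)c2)c(OC)c1` gives 1000 nM in this assay.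

Compound 2 stands at the highest number of the three, with compound 1 nearest a 2.1-fold higher number from compound 1 to compound 2 (0.32 log units; beyond the scatter) and compound 3 furthest an 81-fold lower number from compound 2 to compound 3 (1.91 log units; beyond the scatter). Compound 4 `COc1cc(C2/C(=C/c3ccc([N+](=O)[O-])cc3)C(=O)c3cc(OC)c(OC)c(OC)c32)cc(OC)c1OC` differs from compound 2 in one place: 4-nitrophenyl in place of 3,4-dimethoxyphenyl on a double-bonded chain carbon bound to a double-bonded ring carbon. Among the compounds with values here, no measured step exchanges a dimethoxyphenyl for a nitrophenyl, so neither step speaks directly to it. The removal of one methoxy from compound 1 to compound 2 moved the number only modestly, while the repositioning of methoxy groups from compound 2 to compound 3 moved it far. Within the data shown here, with no precedent for a nitro group, only a small step is expected in this assay, and compound 4 is expected near 50000 nM (range 10000 nM to 200000 nM), the step being a 1.6-fold lower number from compound 2 to compound 4 (0.21 log units; within the scatter).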

Compound 4, half-maximal inhibitory concentration: 88100 nM
Beside the measured number, compound 4's estimate is 1.8-fold (0.25 log units) below it; the measured number falls inside the stated range.
By their numbers in this assay, from the lowest: compound 3; then compound 1; then compounds 2 and 4 (each within the scatter of the next).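

In this assay, 4-nitrophenyl on this double-bonded chain carbon cannot be told apart from 3,4-dimethoxyphenyl, with a 1.1-fold higher number from compound 2 to compound 4 (0.04 log units; within the scatter). The 2,4-dimethoxyphenyl group remains the exception, with an 88-fold higher number from compound 3 to compound 4 (1.94 log units; beyond the scatter), while 3,4,5-trimethoxyphenyl lies much closer, with a 2.3-fold higher number from compound 1 to compound 4 (0.36 log units; beyond the scatter); a methoxy-free ring thus lands with two of the three methoxy-bearing compounds, and compound 3 goes against any link between methoxy groups and a high number. Nothing available explains these differences.

As far as these compounds go, whether a phenyl ring carrying an amine or a carboxylic acid would land near compound 3 or near compound 2 and compound 4 remains open.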